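This account rests on a few compounds, and the source may have more. Where it says the series, first, only, none or still open, it means among the compounds named here.

Three compounds share one core and carry a two-carbon chain from an oxygen on an aromatic ring to a second aromatic ring; they differ only in that second ring. Compound 1 `COc1ccc(CCOc2ccc(-c3c(C)nc(C)c([C@H](OC(C)(C)C)C(=O)O)c3N3CCC(C)(C)CC3)cc2)cc1` carries a 4-methoxyphenyl, compound 2 `COc1cccc(CCOc2ccc(-c3c(C)nc(C)c([C@H](OC(C)(C)C)C(=O)O)c3N3CCC(C)(C)CC3)cc2)c1` a 3-methoxyphenyl, and compound 3 `Cc1nc(C)c([C@H](OC(C)(C)C)C(=O)O)c(N2CCC(C)(C)CC2)c1-c1ccc(OCCc2ccc(F)cc2F)cc1` a 2,4-difluorophenyl. In an ADME assay on microsomes from liver (Rattus norvegicus) for metabolic stability, read by LC-MS, tested at 0.5 uM (a lower number here means that the compound disappears faster, a higher number that the compound lasts longer), compound 1 gives > 2 h, which is a limit of the assay rather than a number. In this assay compound 2 gives > 2 h, again a limit. In this assay compound 3 gives > 2 h, also a limit. Because of the limit of > 2 h in this assay, at which 3 of the 3 values shown sit, none of the steps between these three can be sized: a step that the two limits leave unreadable from compound 1 to compound 2, a step that the two limits leave unreadable from compound 1 to compound 3 and a step that the two limits leave unreadable from compound 2 to compound 3 all stay hidden. Compound 3 thus stands at the limit, level with everything measured so far.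

Compound 4 `Cc1nc(C)c([C@H](OC(C)(C)C)C(=O)O)c(N2CCC(C)(C)CC2)c1-c1ccc(OCCc2cc(F)c(F)cc2F)cc1` differs from compound 3 by fluoro in place of hydrogen on an aromatic carbon, so the 2,4-difluorophenyl becomes a 2,4,5-trifluorophenyl. Within the data shown here, the measured steps that bear on this change are all unreadable, so they give no size and no direction to expect; the only guide is that every value seen sits at the limit. Compound 4 is therefore expected to reach about 2.5 h in this assay, within a range of 1.2 h to 4 h. The expected step is a step that the limit leaves unreadable from compound 3 to compound 4, most likely again reported as a limit.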

Compound 4, half-life: > 2 h
Compound 4 ended at the assay's limit; the forecaster's own chance of this, stated with the estimate: 75%; the middle value is on the limit's open side.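

In this assay compound 4 gives > 2 h, which is a limit and not a number. The steps linking compound 4 to compound 1, compound 2 and compound 3 cannot be sized: the limit of > 2 h in this assay, at which 4 of the 4 values shown sit.

The compounds shown leave open how long any of the four actually lasts, and whether changing the second aromatic ring alters that.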